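A few compounds are considered here, and "the series" means these few. Any claim that something is new, unique, unknown or untested is made for them only; others in the source may bear on it.

Compounds measured in a toxicity assay on CCRF-CEM cells (Homo sapiens) for cytotoxicity; a higher number here means that more compound is tolerated, a lower number that less compound is tolerated:

Compound 1, `COC(=O)c1cccc2c1nc(-c1c(F)cccc1F)n2Cc1c(F)cccc1F`: 57.7 uM
Compound 2, `Oc1cccc2c1nc(-c1c(F)cccc1F)n2Cc1c(F)cccc1F`: > 100 uM
Compound 3, `Nc1cccc2c1nc(-c1c(F)cccc1F)n2Cc1c(F)cccc1F`: 26.3 uM

The value of compound 2 in this assay is a limit of the assay, not a number (the limit of > 100 uM in this assay, at which 1 of the 3 values shown sits). Among the two numbers that are known, compound 3 stands lowest, with compound 1 nearest at a gap of a 2.2-fold lower number from compound 1 to compound 3 (0.34 log units; beyond the scatter). The step from the hydroxy compound to the amino compound is also known: an at least 3.8-fold lower number from compound 2 to compound 3 (0.58 log units; beyond the scatter).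

The step now followed leads from compound 3 to compound 4, `CC(=O)N(C)Cc1cccc2c1nc(-c1c(F)cccc1F)n2Cc1c(F)cccc1F`. The change is (acetyl(methyl)amino)methyl in place of amino on an aromatic carbon. For the measured compounds named here, no measured step replaces the amino by a group of this kind, so the closest guides are the two steps that involve the amino: both changes away from amino went to a higher number in this assay, by a 2.2-fold lower number from compound 1 to compound 3 (0.34 log units; beyond the scatter) read in reverse and by an at least 3.8-fold lower number from compound 2 to compound 3 (0.58 log units; beyond the scatter) read in reverse. On that basis a modest rise beyond the scatter is expected for compound 4, of about a 1.9-fold higher number from compound 3 to compound 4 (0.28 log units; within the scatter). Compound 4 is therefore estimated to give 50 uM in this assay, within a range from 20 uM to 100 uM.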

Compound 4, half-maximal toxic concentration: 20.6 uM
The estimate for compound 4 lay 2.4-fold (0.39 log units) above the measured number, within the range that was stated.
By their numbers in this assay, from the lowest: compounds 4 and 3 (each within the scatter of the next); then compound 1. At a limit, above all of these: compound 2.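

In this assay, (acetyl(methyl)amino)methyl in place of amino on this aromatic carbon gives a 1.3-fold lower number from compound 3 to compound 4 (0.11 log units; within the scatter), so the two groups cannot be told apart here, although the entering group is far larger by heavy atoms and has no hydrogen-bond donor. This breaks the earlier picture in which every change away from amino went to a higher number, and compound 4 is the compound that goes against it: replacing methoxycarbonyl with the new group gives a 2.8-fold lower number from compound 1 to compound 4 (0.45 log units; beyond the scatter), so a carbonyl in the substituent does not by itself place a compound with compound 1. The step from the hydroxy compound, an at least 4.8-fold lower number from compound 2 to compound 4 (0.68 log units; beyond the scatter), starts from a limit of the assay and not a number: the limit of > 100 uM in this assay, at which 1 of the 4 values shown sits.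

The compounds shown leave open which part of the (acetyl(methyl)amino)methyl group goes with this result, as a plain aminomethyl, a methyl amide with the carbonyl turned around or a simple methyl on the same carbon could separate the nitrogen, the acetyl and the added carbon. They also leave open whether a carboxylic acid in place of methoxycarbonyl would stand nearer to the hydroxy compound or to compound 1.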